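Chloro to bromo on the aromatic ring: compound 3 to 4

The compounds below may be only part of what the source reports. "The series", "measured", "known", "first", "only" and "open" are said of these compounds alone.

Compound 1, `CC(=O)OC/C(=C\c1ccccc1Br)C(=O)c1ccccc1`: 21000 nM
Compound 2, `O=C(OC/C(=C\C1CCCCC1)C(=O)c1ccccc1)c1ccccc1`: 19000 nM
Compound 3, `CC(=O)OC/C(=C/c1ccccc1Cl)C(=O)c1ccccc1`: 22000 nM

Of the compounds shown here, three have been tested so far in a functional assay on WiDr cells (Homo sapiens) for inhibition, read by sulforhodamine B assay, with a stated time of 48 h; a lower number here means a stronger inhibitor of growth, a higher number a weaker inhibitor of growth. Compound 3 gives 22000 nM in this assay, the highest of the three numbers, yet the gaps to the other two are small: compound 1 gives 21000 nM and compound 2 gives 19000 nM, and both differ from compound 3 by less than the usual scatter of this assay. On these numbers, then, the three compounds cannot be told apart.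

Compound 4, `CC(=O)OC/C(=C/c1ccccc1Br)C(=O)c1ccccc1`, has not yet been measured. It differs from compound 3 in one place: bromo in place of chloro on an aromatic carbon. For the measured compounds named here, no measured pair in this set shows the same exchange, so there is no step from which to read its size. With the three measured compounds sitting so close together, no shift beyond the scatter is expected here. Compound 4 is estimated at 21000 nM in this assay, within a range from 9000 nM to 50000 nM, which means an expected step of a 1.0-fold lower number from compound 3 to compound 4 (0.02 log units; within the scatter) of no real size.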

Compound 4, concentration for 50% growth inhibition: 18000 nM
Compound 4: the middle estimate sits 1.2-fold (0.07 log units) above what was measured; the range from low to high includes it.
By their numbers in this assay, from the lowest: compounds 4, 2, 1 and 3 (each within the scatter of the next).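

In this assay, the exchange of 2-chlorophenyl for 2-bromophenyl gives a 1.2-fold lower number from compound 3 to compound 4 (0.09 log units; within the scatter), so these two halogens cannot be told apart at this place on the aromatic ring, ortho to a large group. For the compounds shown here, the result also provides a first comparison of double-bond geometry, a 1.2-fold lower number from compound 1 to compound 4 (0.07 log units; within the scatter), and that comparison isolates a single feature: the fact that compounds 1 and 4 differ only in the configuration as drawn. In this bromo pair, the E and Z forms as drawn cannot be told apart in this assay.

As far as these compounds go, it remains open whether a less similar group at this place, such as an amine or a carboxylic acid, would shift the number beyond the scatter. Both steps stay within the scatter, so they do not show which parts of the shared core matter for growth inhibition.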